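The source may report more compounds than this note shows. Statements on the series, on what has been measured and on what is new or still open speak of the compounds shown alone.

Compound 1 `CC1(C)[C@H]2CC[C@]1(C)N(Cc1cn(-c3cccc(F)c3)nn1)C(=O)C2`: 80 nM
Compound 2 `CC1(C)[C@H]2CC[C@]1(C)N(Cc1cn(-c3ccccc3O)nn1)C(=O)C2`: 120 nM
Compound 3 `COc1ccc(-n2cc(CN3C(=O)C[C@@H]4CC[C@@]3(C)C4(C)C)nn2)cc1`: 100 nM

In a functional assay on HepG2 cells (Homo sapiens) for inhibition, read by MTT assay, with a stated time of 24 h (a higher number here means a weaker inhibitor, a lower number a stronger inhibitor), compound 1 has the lowest of the three numbers shown, yet this says little: the step of a 1.3-fold higher number from compound 1 to compound 3 (0.10 log units; within the scatter) and the step of a 1.5-fold higher number from compound 1 to compound 2 (0.18 log units; within the scatter) both lie within the scatter, as does the step of a 1.2-fold lower number from compound 2 to compound 3 (0.08 log units; within the scatter). Compound 4 `Cc1cccc(-n2cc(CN3C(=O)C[C@@H]4CC[C@@]3(C)C4(C)C)nn2)c1` differs from compound 1 by methyl in place of fluoro on an aromatic carbon. The three measured steps all exchange the group on the aromatic ring attached to the aromatic nitrogen, and none of them moved the number beyond the scatter, so a change at the same ring is expected to behave alike. The expected step is therefore a 1.1-fold higher number from compound 1 to compound 4 (0.05 log units; within the scatter), none beyond the scatter. For compound 4 the estimated value is 90 nM, with a range from 45 nM to 180 nM.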

Compound 4, half-maximal inhibitory concentration: 300 nM
Estimate against measurement, compound 4: 3.3-fold (0.52 log units) below; the whole stated range lies below it.
By their numbers in this assay, from the lowest: compounds 1, 3 and 2 (each within the scatter of the next); then compound 4.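

In this assay, the group on this ring does matter: methyl in place of fluoro gives a 3.8-fold higher number from compound 1 to compound 4 (0.57 log units; beyond the scatter) even though each is a single heavy atom on the same aromatic carbon. For the compounds shown here, compound 4 also separates from the other two compounds, with a 3.0-fold higher number from compound 3 to compound 4 (0.48 log units; beyond the scatter) and a 2.5-fold higher number from compound 2 to compound 4 (0.40 log units; beyond the scatter), so only the steps to the 3-methylphenyl compound lie beyond the scatter. Nothing available here explains this difference.

Going by these compounds, whether other carbon groups at this place behave like methyl remains open. Ethyl, trifluoromethyl or an amine on the same aromatic carbon would help to show how far the effect extends.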